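Trading 2-(methylsulfanyl)phenyl for 4-chlorophenyl

A few compounds are considered here, and "the series" means these few. Any claim that something is new, unique, unknown or untested is made for them only; others in the source may bear on it.

Of the compounds shown here, two have been tested so far in a functional assay on MCF7 cells (Homo sapiens) for cytotoxicity, with a stated time of 48 h; on this read-out lower numbers stand for stronger inhibition and higher numbers for weaker inhibition. Compound 1 `COc1cc(O)c(C(=O)/C=C/c2ccc(F)cc2)c(OC)c1` gives 8800 nM, and compound 2 `COc1cc(OC)c(C(=O)/C=C/c2ccccc2SC)c(OC)c1` gives 9300 nM. These two numbers lie within the usual scatter of each other, so compound 2 cannot be ranked against compound 1.

Compound 3 `COc1cc(OC)c(C(=O)/C=C/c2ccc(Cl)cc2)c(OC)c1` has not yet been measured. It carries 4-chlorophenyl in place of 2-(methylsulfanyl)phenyl on a double-bonded chain carbon bound to a double-bonded chain carbon. Going by the values given here, no measured pair differs in just one place, so this change has no direct precedent here. Among the compounds with values here, the only guide is that compound 1 at 8800 nM and compound 2 at 9300 nM fall so close together. I therefore expect no change beyond the scatter, and the direction is uncertain. The estimated step is a 1.2-fold lower number from compound 2 to compound 3 (0.09 log units; within the scatter). In this assay the estimated value for compound 3 is 7500 nM, with a likely range from 3000 nM to 18000 nM.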

Compound 3, half-maximal inhibitory concentration: 7500 nM
Compound 3: the middle estimate sits on the measured number at the digits printed; the range from low to high includes it.
By their numbers in this assay, from the lowest: compounds 3, 1 and 2 (each within the scatter of the next).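

Going by these compounds alone, this is the first direct reading of a change at this position, the double-bonded chain carbon bound to a double-bonded chain carbon. In this assay, trading 2-(methylsulfanyl)phenyl for 4-chlorophenyl gives a 1.2-fold lower number from compound 2 to compound 3 (0.09 log units; within the scatter) and so does not separate the two compounds, even though a sulfur-bearing group leaves and a chlorine-bearing group enters. No other measurement is available to explain this result.

Going by these compounds, both groups compared here are phenyl rings carrying one substituent, so it remains open whether a different kind of group at this position, such as a carboxylic acid or an amine on a longer chain, would move the number beyond the scatter. On these data alone, it also remains open whether this same swap would leave the number within the scatter on the core of compound 1.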